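This account rests on a few compounds, and the source may have more. Where it says the series, first, only, none or still open, it means among the compounds named here.

Working notes on the series in an ADME assay on HEK293 cells (Homo sapiens) for cytotoxicity, with a stated time of 72 h; a lower number here means that less compound is needed, a higher number that more compound is needed for the effect.

Compound 1 `COc1ccc(/C=C/[C@@](C)(/C=C/c2ccc(O)c(/C=C/C(=O)OCc3ccccc3)c2)CCC=C(C)C)cc1` carries a benzyl ester on the shared core. In this assay compound 1 gives only a limit, > 36600 nM. Compound 2 `C=C[C@@](C)(/C=C/c1ccc(Nc2ccc(OC)c(OC)c2)cc1)CCC=C(C)C` has an anilino group on the core. In this assay compound 2 likewise gives only a limit, > 36600 nM. Compound 3 `C=C[C@@](C)(/C=C/c1ccc(Nc2ccc(OC)c(F)c2)cc1)CCC=C(C)C` keeps that anilino group with fluoro in place of methoxy on an aromatic carbon. In this assay compound 3 again gives only a limit, > 36600 nM. For the measured compounds named here, the one step joining measured compounds that differ in a single place is a step that the two limits leave unreadable from compound 2 to compound 3, and its size cannot be read because of the limit of > 36600 nM in this assay, at which 3 of the 3 values shown sit.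

Compound 4 `C=C[C@@](C)(/C=C/c1ccc(Nc2ccc(Cl)c(Cl)c2)cc1)CCC=C(C)C` differs from compound 3 by 3,4-dichlorophenyl in place of 3-fluoro-4-methoxyphenyl on a nitrogen on an aromatic ring. No measured step bears on this change, and the single step shown gives no size. Compound 3 stands at the limit alongside every other value shown. For compound 4 the expected step is a number no higher from compound 3 to compound 4 (the limit leaves the size open), with no direction that the data support. The estimate for compound 4 is therefore 36600 nM, within 15000 nM to 80000 nM.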

Compound 4, half-maximal effective concentration: > 36600 nM
Compound 4: a limit, no number (the forecaster's own chance of this, stated with the estimate: 70%); the middle value lies on the limit itself.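

No new step can be read between compound 3 and compound 4 in this assay, because both give only a limit: the limit of > 36600 nM in this assay, at which 4 of the 4 values shown sit.

The compounds shown leave open whether any of these structural changes alters the half-maximal effective concentration in this assay, and where the true value of each compound lies.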